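The source may hold more compounds than are shown below. What is called first, only, known or untested is meant among the compounds shown, and "the series" means these compounds.

Working notes on the series, step from compound 3 to compound 4.

Of the compounds shown here, three of the shared core have numbers so far. Compound 1 `Cc1cc2c(F)c(Oc3ncnc(N)c3/C=N/OCCCO)ccc2[nH]1` gives 452 nM in a functional assay on HCT-116 cells (Homo sapiens) for antiproliferative activity; on this read-out higher numbers stand for weaker inhibition and lower numbers for stronger inhibition. Compound 2 `CNCCO/N=C/c1c(N)ncnc1Oc1ccc2[nH]c(C)cc2c1F` gives 3010 nM in this assay, and compound 3 `CCCCO/N=C/c1c(N)ncnc1Oc1ccc2[nH]c(C)cc2c1F` gives 1000 nM in this assay. On these numbers compound 3 stands second highest of the three: compound 1 is nearest, with a 2.2-fold higher number from compound 1 to compound 3 (0.34 log units; beyond the scatter), and compound 2 is furthest, with a 3.0-fold lower number from compound 2 to compound 3 (0.48 log units; beyond the scatter). The third measured step, a 6.7-fold higher number from compound 1 to compound 2 (0.82 log units; beyond the scatter), sets the spread of the set.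

Compound 4 `C=CCO/N=C/c1c(N)ncnc1Oc1ccc2[nH]c(C)cc2c1F` differs from compound 3 in one place: vinyl in place of propyl on a saturated chain carbon bound to an oxygen on an unsaturated carbon. The chain on the oxygen is shortened and gains a double bond, while no hydrogen-bond donor or acceptor leaves or enters. Among the compounds with values here, none of the measured steps changes chain length alone; the nearest, from compound 1 to compound 3, swaps hydroxy for methyl at the chain end and is modest in size. With no donor or acceptor in play, the step is expected to stay small, in either direction, and most likely within the scatter.

Compound 4 is therefore estimated at 900 nM in this assay, between 400 nM and 2200 nM. The expected step is a 1.1-fold lower number from compound 3 to compound 4 (0.05 log units; within the scatter).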

Compound 4, half-maximal inhibitory concentration: 40 nM
For compound 4 the middle estimate is 23-fold (1.35 log units) above the measured one; the whole stated range lies above it.
By their numbers in this assay, from the lowest: compound 4; then compound 1; then compound 3; then compound 2.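

In this assay, the butoxy to allyloxy change gives a 25-fold lower number from compound 3 to compound 4 (1.40 log units; beyond the scatter), so this position responds strongly to a change in which neither the leaving propyl nor the entering vinyl carries a hydrogen-bond donor or acceptor. Within the data shown here, this step exceeds the widest spread among the earlier compounds, a 6.7-fold higher number from compound 1 to compound 2 (0.82 log units; beyond the scatter), and the allyloxy chain also stands well clear of the chains ending in hydroxy and methylamino, with an 11-fold lower number from compound 1 to compound 4 (1.05 log units; beyond the scatter) and a 75-fold lower number from compound 2 to compound 4 (1.88 log units; beyond the scatter), which makes compound 4 the strongest of the four. Nothing at hand explains the size of these steps.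

Still open, on these data alone, is whether the double bond or the shorter chain carries the effect, since both change together in this step; a propoxy group on the same oxygen would separate the two. Also open, as far as these compounds go, is whether the low number extends to a propargyl group, a cyclopropylmethyl group or a longer alkenyl chain at this place, and whether the order of the four holds in any read-out other than this assay.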